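Thioether in place of the benzylamine link on the shared core

The compounds below may be only part of what the source reports. "The series", "measured", "known", "first", "only" and "open" are said of these compounds alone.

Two members of the series carry measurements. Compound 1 `COc1ccc(CNc2nc3cc(N)cc(N)c3nc2-c2ccccc2)cc1OC` gives 34700 nM in a functional assay on 786-0 cells (Homo sapiens) for inhibition, read by sulforhodamine B assay, with a stated time of 48 h; on this read-out lower numbers stand for stronger inhibition of growth and higher numbers for weaker inhibition of growth. For the measured compounds named here, compound 2 `Nc1cc(N)c2nc(-c3ccccc3)c(NCc3ccc(F)cc3)nc2c1` gives 61700 nM in this assay, the highest of the two numbers; the single step of a 1.8-fold higher number from compound 1 to compound 2 (0.25 log units; within the scatter) is within the scatter, so the two compounds are not distinguished.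

Compound 3 `Nc1cc(N)c2nc(-c3ccccc3)c(Sc3ccc(F)cc3)nc2c1` differs from compound 2 by (4-fluorophenyl)sulfanyl in place of (4-fluorobenzyl)amino on an aromatic carbon. Going by the values given here, no measured step alters the link between the core and the 4-fluorophenyl group; the only step on record changes the aryl group itself and stays within the scatter. There is thus no basis for expecting a shift beyond the scatter, and the expected step of a 1.0-fold lower number from compound 2 to compound 3 (0.01 log units; within the scatter) is small. Compound 3 is estimated at 60000 nM, with a range from 20000 nM to 180000 nM, both weak numbers like those of compound 1 and compound 2.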

Compound 3, concentration for total growth inhibition: < 100000 nM
Compound 3 ended at the assay's limit (the forecaster's own chance of this, stated with the estimate: 25%); the middle value does not contradict the limit.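

In this assay compound 3 gives < 100000 nM, a limit of the assay and not a number. The step from compound 2 to compound 3 therefore cannot be read. The compounds shown leave open whether (4-fluorophenyl)sulfanyl in place of (4-fluorobenzyl)amino changes growth inhibition at all.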